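Series notes: chain variation at the amide in compound 3

The compounds below may be only part of what the source reports. "The series", "measured", "known", "first", "only" and "open" are said of these compounds alone.

Measured compounds and values in an assay for inhibition of acyl-CoA:cholesterol acyltransferase (Oryctolagus cuniculus), using microsomes; on this read-out lower numbers stand for stronger inhibition and higher numbers for weaker inhibition:
compound 1 `CCCCCCCCCCCCC(C)(C)C(=O)Nc1c(C)cc(C)c2c1OC(C)(C)C2` gives 33 nM
compound 2 `Cc1cc(C)c(NC(=O)C(C)(C)CCCCCCc2ccccc2)c2c1CC(C)(C)O2` gives 81 nM
compound 3 `Cc1cc(C)c(NC(=O)C(C)(C)CCCc2ccc(CC(C)C)cc2)c2c1CC(C)(C)O2` gives 40 nM

Compound 3 sits second highest of the three numbers. Its nearest neighbour is compound 1, a step within the scatter a 1.2-fold higher number from compound 1 to compound 3 (0.08 log units; within the scatter); the gap to compound 2 is a modest one beyond the scatter a 2.0-fold lower number from compound 2 to compound 3 (0.31 log units; beyond the scatter). The remaining step, a 2.5-fold higher number from compound 1 to compound 2 (0.39 log units; beyond the scatter), is also modest.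

Compound 4 `Cc1cc(C)c(NC(=O)C(C)(C)CCCCOc2ccc(Cl)cc2)c2c1CC(C)(C)O2` carries the change ((4-chlorophenoxy)methyl in place of 4-isobutylphenyl on a saturated chain carbon, four bonds along the chain from a carbonyl carbon). The two steps that end at compound 3 bear on it: exchanging nonyl for 4-isobutylphenyl at this chain carbon cost nothing beyond the scatter, while exchanging 3-phenylpropyl for 4-isobutylphenyl gave a modest gain. Among the compounds with values here, a group with an oxygen in the chain and a chlorine on the ring is new to the series, so no measured step matches it directly. Compound 4 is therefore expected to lie near compound 3, with a modest loss more likely than a gain, an estimated step of a 1.5-fold higher number from compound 3 to compound 4 (0.18 log units; within the scatter). The estimate for compound 4 in this assay is 60 nM, with a range of 25 nM to 150 nM.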

Compound 4, half-maximal inhibitory concentration: 330 nM
Beside the measured number, compound 4's estimate is 5.5-fold (0.74 log units) below it; measured number above the stated range.
By their numbers in this assay, from the lowest: compounds 1 and 3 (each within the scatter of the next); then compound 2; then compound 4.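

In this assay this saturated chain carbon no longer looks indifferent to what it carries: among the earlier chains the steps stayed small, but (4-chlorophenoxy)methyl in place of 4-isobutylphenyl gives an 8.3-fold higher number from compound 3 to compound 4 (0.92 log units; beyond the scatter) and the comparisons with the other chains give a 4.1-fold higher number from compound 2 to compound 4 (0.61 log units; beyond the scatter) and a 10-fold higher number from compound 1 to compound 4 (1.00 log units; beyond the scatter). The change brings in the oxygen and the chlorine together, and the compounds shown do not separate their contributions to this loss. Nothing at hand explains the loss.

Within the data shown here, open is whether a 4-chlorophenyl group on an all-carbon chain keeps the values of the earlier compounds, or whether an unsubstituted phenoxy group already carries the loss. A phenoxy group on a longer chain would also show whether the length of the link matters at this place.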